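The source may report more compounds than this note shows. Statements on the series, on what has been measured and on what is new or still open speak of the compounds shown alone.

Compound 1 `COc1ccc(C2=C(c3cc(OC)c(OC)c(OC)c3)C(=O)CC2O[SiH2]C(C)(C)C)cc1OC` gives, as a limit of the assay, > 100 ug/mL in an ADME assay on HEp-2 cells (Homo sapiens) for cytotoxicity, read by MTT assay, with a stated time of 72 h; on this read-out lower numbers stand for stronger inhibition and higher numbers for weaker inhibition.
Compound 2 `COc1ccc(C2=C(c3cc(OC)c(OC)c(OC)c3)C(=O)C(OC(C)=O)C2)cc1O` gives, as a limit, > 100 ug/mL in this assay.
Compound 3 `O/N=C1/CC(O)C(c2ccccc2)=C1c1ccccc1` gives, as a limit, > 100 ug/mL in this assay.

In this assay every value shown is a limit, not a number: the limit of > 100 ug/mL in this assay, at which 3 of the 3 values shown sit. Among the measured compounds shown here, compound 1 therefore stands at that limit together with the other two measured compounds, and no pair of measured compounds differs in one place, so no measured step is available. Compound 4 `COc1cc(C2=C(c3cc(C)c(OC)c(C)c3)C(O[SiH2]C(C)(C)C)CC2=O)cc(OC)c1OC` differs from compound 1 by 4-methoxy-3,5-dimethylphenyl in place of 3,4-dimethoxyphenyl on a double-bonded ring carbon. For the measured compounds named here, with no measured step to guide it, the step that the limit leaves unreadable from compound 1 to compound 4 is expected to be none beyond the scatter. Compound 4 is expected to give about 150 ug/mL in this assay, within 60 ug/mL to 400 ug/mL, most likely reported again only as a limit.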

Compound 4, half-maximal inhibitory concentration: 26 ug/mL
Beside the measured number, compound 4's estimate is 5.8-fold (0.76 log units) above it; measured number below the stated range.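

In this assay, among the compounds shown here, the change on this double-bonded ring carbon gives an at least 3.8-fold lower number from compound 1 to compound 4 (0.58 log units; beyond the scatter) and yields the only actual number in the set. For the compounds shown here, it shows that this position can move the read-out, which the earlier compounds could not show, as all of them stood at one limit: the limit of > 100 ug/mL in this assay, at which 3 of the 4 values shown sit. The value for compound 1 is itself only a limit, so the full size of the step cannot be read.

Going by these compounds, it remains open whether the two methyl groups or the lost methoxy group accounts for the step. Also open, on these data alone, is how an amine or a carboxylic acid on this phenyl ring would read.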